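A Fluoro Substituent Entering the Anilino Ring

The compounds below may be only part of what the source reports. "The series", "measured", "known", "first", "only" and "open" are said of these compounds alone.

Compound 1, `COC(=O)c1c(Nc2ccccc2)sc(C(=O)c2ccc(OC)cc2)c1C`, gives 36.9% in a functional assay, with a stated time of 150 min, tested at 25 ug/mL; on this read-out higher numbers stand for a stronger effect at the one concentration tested and lower numbers for a weaker effect. Compound 2, `COC(=O)c1c(Nc2ccc(Cl)cc2)sc(C(=O)c2ccc(OC)cc2)c1C`, gives "not active" (no number reported) in this assay. Compound 3, `COC(=O)c1c(Nc2ccccc2)sc(C(=O)c2ccc(C)cc2)c1C`, gives 8.16% in this assay.

Compound 3 stands lowest of the two numbers; its nearest neighbour is compound 1, separated by a number 28.7 percentage points lower from compound 1 to compound 3 (beyond the scatter). Compound 4, `COC(=O)c1c(Nc2ccc(F)cc2)sc(C(=O)c2ccc(C)cc2)c1C`, differs from compound 3 by fluoro in place of hydrogen on an aromatic carbon. Going by the values given here, no measured step covers this change. Among the compounds with values here, the only pair that puts a halogen onto that ring is compound 1 and compound 2: compound 1 gives 36.9%, whereas compound 2 gives "not active" (no number reported). Since compound 3 already sits low, the step of a number 3.2 percentage points lower from compound 3 to compound 4 (within the scatter) is expected to be none beyond the scatter or slightly downward, with some chance of no number at all. Compound 4 is estimated at 5%, within 0% to 20%.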

Compound 4, a percentage reported as activity, at one concentration (the size of the read-out at that concentration, not a potency): "not active" (no number reported)
Nothing numeric was reported for compound 4, so the estimate cannot be set against anything.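

In this assay compound 4 gives "not active" (no number reported), so no step from compound 3 to compound 4 can be read, and no data shown explain this result. The compounds shown leave open how far fluoro in place of hydrogen shifts the read-out.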